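From a 4-fluorophenyl to a 4-methylbenzyl amide

This account rests on a few compounds, and the source may have more. Where it says the series, first, only, none or still open, it means among the compounds named here.

In a functional assay on LoVo cells (Homo sapiens) for inhibition, read by MTT assay, with a stated time of 72 h (on this read-out higher numbers stand for weaker inhibition and lower numbers for stronger inhibition), compound 1 `COc1cc(NC(=O)/C=C/c2cccc(OCc3ccccc3)c2)cc(OC)c1OC` gives the highest number (21700 nM) and compound 2 `C=C(Br)C(=O)Nc1cccc(/C=C/C(=O)Nc2cccc3ccccc23)c1` gives the lowest (1160 nM). Compound 3 `C=C(Br)C(=O)Nc1cccc(/C=C/C(=O)Nc2ccc(F)cc2)c1` lies between them (4800 nM), second highest of the three, and its gaps to both neighbours lie beyond the usual scatter. Compound 4 `C=C(Br)C(=O)Nc1cccc(/C=C/C(=O)NCc2ccc(C)cc2)c1` has 4-methylbenzyl in place of 4-fluorophenyl on an amide-type nitrogen. Going by the values given here, no measured pair shows a change in one place only, so the data offer no direct guide to this replacement. A small shift toward a lower number, within the scatter, is therefore expected in this assay (a 1.2-fold lower number from compound 3 to compound 4 (0.08 log units; within the scatter)). Compound 4 is estimated at 4000 nM with an expected range (1500 nM to 11000 nM).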

Compound 4, half-maximal inhibitory concentration: 1900 nM
Beside the measured number, compound 4's estimate is 2.1-fold (0.32 log units) above it, within the range that was stated.
By their numbers in this assay, from the lowest: compounds 2 and 4 (each within the scatter of the next); then compound 3; then compound 1.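

Going by these compounds alone, on an amide-type nitrogen, the first single-place comparison in this assay shows that this substituent can shift the read-out: 4-methylbenzyl in place of 4-fluorophenyl gives a 2.5-fold lower number from compound 3 to compound 4 (0.40 log units; beyond the scatter). The step is modest but beyond the scatter, and nothing measured explains it. The compounds shown do not separate the contribution of the methyl group from that of the benzyl linkage, since neither 4-fluorobenzyl nor 4-methylphenyl is among them. Also open, as far as these compounds go, is how an amine or a carboxylic acid on this ring would read out.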